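Moving the Sulfonyl Attachment Around the Thiazole Ring

The source may hold more compounds than are shown below. What is called first, only, known or untested is meant among the compounds shown, and "the series" means these compounds.

In a functional assay (Cavia porcellus) with sulfonylurea receptors; K-ATP channels (Homo sapiens) as the target (a lower number here means a stronger inhibitor, a higher number a weaker inhibitor), compound 1 `CC(O)(C(=O)Nc1ccc(S(=O)(=O)c2ccc(F)cc2)cc1)C(F)(F)F` gives 8600 nM. Compound 2 `Cc1ccc(S(=O)(=O)c2ccc(NC(=O)C(C)(O)C(F)(F)F)cc2)cc1` reaches only the limit > 30000 nM in this assay. Compound 3 `CC(O)(C(=O)Nc1ccc(S(=O)(=O)c2nccs2)cc1)C(F)(F)F` gives 1400 nM, the lowest of the two numbers measured; its nearest neighbour is compound 1, with a 6.1-fold lower number from compound 1 to compound 3 (0.79 log units; beyond the scatter). The step of an at least 21-fold lower number from compound 2 to compound 3 (1.33 log units; beyond the scatter) is larger still, though one side of it sits at the limit of > 30000 nM in this assay, at which 1 of the 3 values shown sits. Compound 4 `CC(O)(C(=O)Nc1ccc(S(=O)(=O)c2cncs2)cc1)C(F)(F)F` differs from compound 3 by 1,3-thiazol-5-yl in place of 1,3-thiazol-2-yl on a sulfonyl sulfur. Both measured steps replaced a 4-fluorophenyl or 4-methylphenyl group with the thiazole; neither moves the point at which the thiazole meets the sulfonyl sulfur, so they give no direct guide. The expected step is therefore a 1.4-fold higher number from compound 3 to compound 4 (0.15 log units; within the scatter), inside the scatter. Compound 4 is estimated at 2000 nM, with a range of 700 nM to 6000 nM.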

Compound 4, half-maximal inhibitory concentration: 7700 nM
For compound 4 the middle estimate is 3.9-fold (0.59 log units) below the measured one; measured number outside the range, above it.
By their numbers in this assay, from the lowest: compound 3; then compounds 4 and 1 (each within the scatter of the next). At a limit, above all of these: compound 2.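

Where the thiazole meets the sulfonyl sulfur matters in its own right: with the same atoms joined differently, the step is a 5.5-fold higher number from compound 3 to compound 4 (0.74 log units; beyond the scatter). The advantage seen earlier for a thiazole therefore belongs, among these compounds, to the 1,3-thiazol-2-yl group alone, since the step to the 1,3-thiazol-5-yl group from 4-fluorophenyl is a 1.1-fold lower number from compound 1 to compound 4 (0.05 log units; within the scatter). Against 4-methylphenyl the step is an at least 3.8-fold lower number from compound 2 to compound 4 (0.59 log units; beyond the scatter), a size bounded only by an assay limit: the limit of > 30000 nM in this assay, at which 1 of the 4 values shown sits.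

The compounds shown do not explain why the attachment point matters. On these data alone, whether a pyridin-2-yl group on the sulfonyl sulfur would match the 1,3-thiazol-2-yl group also remains open.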